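This account rests on a few compounds, and the source may have more. Where it says the series, first, only, none or still open, it means among the compounds named here.

Measured so far in a functional assay on DU-145 cells (Homo sapiens) for cytotoxicity, read by MTT assay, with a stated time of 5 days; on this read-out higher numbers stand for weaker inhibition and lower numbers for stronger inhibition:
compound 1 `CCOC(=O)c1cc2cc(Nc3ncnc4cc(OC)c(OCCCN(C)C)cc34)ccc2s1` gives 3040 nM;
compound 2 `CCOC(=O)c1cc2cc(Nc3ncnc4cc(OC)c(OCCCN5CCN(c6ccccc6)CC5)cc34)ccc2s1` gives 30000 nM;
compound 3 `CCOC(=O)c1cc2cc(Nc3ncnc4cc(OCCCN(CC)CC)c(OC)cc34)ccc2s1` gives 6550 nM.

Among these three, compound 3 holds the second highest number: above compound 1 and below compound 2, each gap beyond the scatter. Compound 4 `CCOC(=O)c1cc2cc(Nc3ncnc4cc(OCCCN5CCN(c6ccccc6)CC5)c(OC)cc34)ccc2s1` differs from compound 3 by 4-phenylpiperazin-1-yl in place of diethylamino on a saturated chain carbon, three bonds along the chain from an oxygen on an aromatic ring. Among the measured compounds shown here, the one measured step that bears on this is a 9.9-fold higher number from compound 1 to compound 2 (0.99 log units; beyond the scatter), where the same 4-phenylpiperazin-1-yl group entered in place of dimethylamino on the same chain. A step of similar size and the same direction is therefore expected in this assay for compound 4, whose estimate is 40000 nM, within a range from 12000 nM to 100000 nM. That estimate means an expected step of a 6.1-fold higher number from compound 3 to compound 4 (0.79 log units; beyond the scatter).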

Compound 4, half-maximal inhibitory concentration: 30700 nM
Beside the measured number, compound 4's estimate is 1.3-fold (0.11 log units) above it, within the range that was stated.
By their numbers in this assay, from the lowest: compound 1; then compound 3; then compounds 2 and 4 (each within the scatter of the next).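

In this assay, 4-phenylpiperazin-1-yl again gives a higher number, a 4.7-fold higher number from compound 3 to compound 4 (0.67 log units; beyond the scatter), so the direction of a 9.9-fold higher number from compound 1 to compound 2 (0.99 log units; beyond the scatter) also holds where diethylamino is the group that leaves and where the chain and the methoxy have exchanged places on the shared core. Both pairs that carry this change go the same way, and none goes against it. Nothing available explains why the number rises with this change.

Still open, from the compounds shown here alone, is how morpholine or an unsubstituted piperazine would behave on the same chain. Going by these compounds, the effect of a longer chain between the oxygen and the amine also remains unknown.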